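Fluorine pattern to chlorine-fluorine: expected outcome for compound 3

The source may report more compounds than this note shows. Statements on the series, on what has been measured and on what is new or still open speak of the compounds shown alone.

Of the compounds shown here, two have been measured in a functional assay on MDA-MB-231 cells (Homo sapiens) for cytotoxicity, read by MTT assay, with a stated time of 72 h; a lower number here means a stronger inhibitor, a higher number a weaker inhibitor. Compound 1, `COc1cc2c(Oc3ccc(NC(=O)N/N=C/c4ccc([N+](=O)[O-])cc4)cc3F)ccnc2cc1OCCCN1CCC(C)CC1`, gives 870 nM. Compound 2, `COc1cc2c(Oc3ccc(NC(=S)N/N=C/c4ccc(F)c(F)c4)cc3F)ccnc2cc1OCCCN1CCCCC1`, gives 1400 nM. Compound 2 stands beside compound 1 on these numbers: the gap between them is within the scatter, so the two readings are not separated. Compound 3, `COc1cc2c(Oc3ccc(NC(=S)N/N=C/c4ccc(F)cc4Cl)cc3F)ccnc2cc1OCCCN1CCCCC1`, is the next compound to be measured; it differs from compound 2 by 2-chloro-4-fluorophenyl in place of 3,4-difluorophenyl on a carbon with a double bond to nitrogen. Among the measured compounds shown here, no measured pair in the set shows this exchange, so nothing observed supports a step in either direction; the expectation is that this assay stays about where compound 2 stands, with any step inside the scatter. Compound 3 is therefore estimated at 1400 nM, with a range of 500 nM to 4000 nM. The step expected from compound 2 to compound 3 is no change at the digits printed from compound 2 to compound 3 (within the scatter), none beyond the scatter.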

Compound 3, half-maximal inhibitory concentration: 1400 nM
Beside the measured number, compound 3's estimate shows no gap at the digits printed; the measured number falls inside the stated range.
By their numbers in this assay, from the lowest: compounds 1, 2 and 3 (each within the scatter of the next).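

Among the compounds shown here, the exchange of 3,4-difluorophenyl for 2-chloro-4-fluorophenyl on a carbon with a double bond to nitrogen gives, in this assay, no change at the digits printed from compound 2 to compound 3 (within the scatter) and is the first single-place step read. Both groups carry the same count of heavy atoms and a single six-membered aromatic ring of carbon only, so at this place a chlorine can enter and a fluorine leave without a step beyond the scatter, at least for this one pair. Nothing available on these compounds offers an explanation for this flat result.

As far as these compounds go, whether the flat reading extends beyond these two halogenated phenyl groups remains open, since a single pair cannot define the tolerance of the position. A phenyl ring bearing a carboxylic acid or an amine, or a pyridine ring, at the same place would test whether this assay responds to this position at all.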